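From bromo to amino on compound 2

The source may report more compounds than this note shows. Statements on the series, on what has been measured and on what is new or still open speak of the compounds shown alone.

Values in a functional assay on KYSE-450 cells (Homo sapiens) for inhibition, read by MTT assay, with a stated time of 48 h; on this read-out lower numbers stand for stronger inhibition and higher numbers for weaker inhibition:
- compound 1 `COc1cc(NCc2ccccc2)cc(OC)c1OC` gives > 80000 nM (a limit of the assay, not a number)
- compound 2 `COc1ccc(CNc2cc(OC)c(OC)c(OC)c2)cc1Br` gives 39800 nM
- compound 3 `C/C=C/C(=O)N(Cc1ccc(OC)c(Br)c1)c1cc(OC)c(OC)c(OC)c1` gives 10500 nM

Of the two actual numbers in this assay the higher belongs to compound 2. Among the measured compounds shown here, the only measured step is a 3.8-fold lower number from compound 2 to compound 3 (0.58 log units; beyond the scatter) and it falls on a nitrogen, not on the aromatic carbon in question here.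

Compound 4 `COc1ccc(CNc2cc(OC)c(OC)c(OC)c2)cc1N` differs from compound 2 as follows: amino in place of bromo on an aromatic carbon, ortho to a methoxy group. For the measured compounds named here, no measured step touches this place, so the step above is only a rough guide to size, and the direction is uncertain. A modest move to a lower number is expected. The estimated step is a 2.5-fold lower number from compound 2 to compound 4 (0.40 log units; beyond the scatter) and it carries wide uncertainty. For compound 4 the expected value is 16000 nM with an estimated range from 4000 nM to 60000 nM in this assay.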

Compound 4, half-maximal inhibitory concentration: 2210 nM
The estimate for compound 4 lay 7.2-fold (0.86 log units) above the measured number, and the stated range ends above it.
By their numbers in this assay, from the lowest: compound 4; then compound 3; then compound 2. At a limit, above all of these: compound 1.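

In this assay amino in place of bromo on an aromatic carbon, ortho to a methoxy group, gives an 18-fold lower number from compound 2 to compound 4 (1.26 log units; beyond the scatter) and so marks this carbon as a place where a swap of one heavy atom matters strongly. The earlier step, a 3.8-fold lower number from compound 2 to compound 3 (0.58 log units; beyond the scatter) on the nitrogen, showed nothing about this place. A hydroxyl or an acetamide at this carbon would test whether the step belongs to amino alone, and amino combined with (prop-1-en-1-yl)carbonyl on the nitrogen would test whether the two steps add. No measurement shown here bears on the cause of the step.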